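This account rests on a few compounds, and the source may have more. Where it says the series, first, only, none or still open, it means among the compounds named here.

Of the compounds shown here, two sharing one core have been measured in an assay on HEK293 cells for inhibition of sodium- and chloride-dependent glycine transporter 1 (Homo sapiens), read by scintillation proximity assay; a lower number here means a stronger inhibitor, a higher number a weaker inhibitor. Compound 1 `O=C(CN(C(=O)c1ccc(-c2ccccn2)cc1)C1CCOCC1)Nc1cc(F)cc(F)c1`, which carries an oxan-4-yl group on the amide-type nitrogen, gives 1000 nM in this assay. Compound 2 `O=C(CN(CC1CCC1)C(=O)c1ccc(-c2ccccn2)cc1)Nc1cc(F)cc(F)c1`, with cyclobutylmethyl on that same nitrogen, gives 126 nM, the lowest of the two numbers, and the change was a 7.9-fold lower number from compound 1 to compound 2 (0.90 log units; beyond the scatter). Compound 3 `COCC(C)N(CC(=O)Nc1cc(F)cc(F)c1)C(=O)c1ccc(-c2ccccn2)cc1` is not yet measured; it differs from compound 2 by 1-(methoxymethyl)ethyl in place of cyclobutylmethyl on an amide-type nitrogen. Going by the values given here, the one measured step bears on this: swapping a ring that holds an oxygen for a carbon-only ring lowered the number markedly, and compound 3 now brings an oxygen back, though in a chain rather than a ring. The number for compound 3 is therefore expected to rise, by a step estimated as a 2.8-fold higher number from compound 2 to compound 3 (0.44 log units; beyond the scatter), smaller than the step seen before. Compound 3 is estimated at 350 nM in this assay, within a range from 150 nM to 1000 nM.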

Compound 3, half-maximal inhibitory concentration in the sodium- and chloride-dependent glycine transporter 1 assay: 1260 nM
Beside the measured number, compound 3's estimate is 3.6-fold (0.56 log units) below it; the whole stated range lies below it.
By their numbers in the sodium- and chloride-dependent glycine transporter 1 assay, from the lowest: compound 2; then compounds 1 and 3 (each within the scatter of the next).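

In the sodium- and chloride-dependent glycine transporter 1 assay, the step to the oxygen-bearing chain is as large as the earlier step to the oxygen-bearing ring: 1-(methoxymethyl)ethyl in place of cyclobutylmethyl gives a 10-fold higher number from compound 2 to compound 3 (1.00 log units; beyond the scatter). Set against the ring, the same chain gives a 1.3-fold higher number from compound 1 to compound 3 (0.10 log units; within the scatter), so on this amide-type nitrogen, whether the oxygen sits in a ring or in a chain makes no readable difference among these compounds. The same change also shifts the reading in a physicochemical assay for lipophilicity; a higher number here means a more lipophilic compound, a lower number a more polar compound: the measured distribution coefficient of compound 2, 3.5, and of compound 3, 3, a number 0.50 log units lower (beyond the scatter) In the physicochemical assay compound 2 gives 3.5 and compound 3 gives 3.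

Still open, from the compounds shown here alone, is whether the oxygen itself matters, as both oxygen-bearing groups also differ from cyclobutylmethyl in their carbon skeleton. A carbon-only open chain such as 2-methylpropyl on this nitrogen would help separate the two, and an amine in the same place would show how a different kind of group fares.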